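Shrinking a furan-2-yl to methyl on the saturated ring carbon

The source may hold more compounds than are shown below. What is called first, only, known or untested is meant among the compounds shown, and "the series" means these compounds.

Measured compounds in a functional assay on SH-SY5Y cells (Homo sapiens) for antiproliferative activity, with a stated time of 24 h, tested at 50 ug/mL; a higher number here means a stronger effect of the compound at the concentration tested, a lower number a weaker effect:
- compound 1 `Cc1cc2c(c(=O)o1)C=C(c1ccccc1)C(CC(C)C)O2`: 81.7%
- compound 2 `Cc1cc2c(c(=O)o1)C=C(C(C)C)C(CC(C)C)O2`: 95.7%
- compound 3 `CC1=Cc2c(cc(C)oc2=O)OC1c1ccco1`: 64.4%

Compound 3 stands lowest of the three numbers. Its nearest neighbour is compound 1, which lies higher by a margin beyond the scatter, and the gap to compound 2 is wider still.

Compound 4 `CC1=Cc2c(cc(C)oc2=O)OC1C` is not yet measured. It differs from compound 3 in one place: methyl in place of furan-2-yl on a saturated ring carbon. A ring group on the saturated ring carbon of the shared core is thus exchanged for the smallest possible chain.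

Among the measured compounds shown here, no measured step changes a group on that same carbon. For the measured compounds named here, the only step available, a number 14 percentage points higher from compound 1 to compound 2 (beyond the scatter), concerns a different ring position, where a phenyl ring gave way to an isopropyl chain and the read-out rose modestly. That step bears on the present change only loosely: it shows that, in this series, replacing a ring by a small chain did not lower inhibition in this assay, but methyl is smaller than isopropyl and the position differs, so a step of at most modest size, upward or none beyond the scatter, seems most plausible.

Compound 4 is therefore expected to give 71%, within a range of 52% to 88%, an estimated step of a number 6.6 percentage points higher from compound 3 to compound 4 (within the scatter).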

Compound 4, a percentage reported as inhibition, at one concentration (the size of the read-out at that concentration, not a potency): 53.8%
Compound 4: middle estimate off by 17.2 percentage points, on the high side; measured number inside the range.
By their numbers in this assay, from the lowest: compound 4; then compound 3; then compound 1; then compound 2.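

Among the compounds shown here, on the saturated ring carbon next to the ring oxygen, the exchange of furan-2-yl for methyl is the first measured change at this position, and in this assay it moves the read-out downward: a number 10.6 percentage points lower from compound 3 to compound 4 (beyond the scatter). A ring giving way to a small chain therefore does not have the same outcome everywhere in these compounds, as the exchange of phenyl for isopropyl on a double-bonded ring carbon went the other way, a number 14 percentage points higher from compound 1 to compound 2 (beyond the scatter), and that earlier step cannot be carried over to this position. The furan-2-yl ring is also not required for a sizeable read-out, as compound 4 with only methyl there still gives 53.8%, but no measurement at hand accounts for the drop.

The compounds shown leave open whether the fall follows from losing the ring or from losing size, which a phenyl ring or an ethyl chain on the same carbon could help to separate. They also leave open how either group would read at other concentrations, since each number here comes from a single concentration and says nothing of potency.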